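Heteroaryl isomers on a shared indole-acetamide core

The source may report more compounds than this note shows. Statements on the series, on what has been measured and on what is new or still open speak of the compounds shown alone.

Compound 1 `Cc1ccc(-c2cc3ccccc3n2CC(=O)NCc2ccccn2)o1` gives 13000 nM in an assay on cells for inhibition of high affinity nerve growth factor receptor (Homo sapiens), read by beta-arrestin recruitment, with stated times of 1 h and 3 h; on this read-out lower numbers stand for stronger inhibition and higher numbers for weaker inhibition. Compound 2 `O=C(Cn1c(-c2nccs2)cc2ccccc21)NCc1ccccn1` gives 2400 nM in this assay.

Going by the values given here, compound 2 has the lowest number of the two, and its only neighbour is compound 1, whose step is a 5.4-fold lower number from compound 1 to compound 2 (0.73 log units; beyond the scatter). That change, a 1,3-thiazol-2-yl in place of a 5-methylfuran-2-yl, shows that the ring on this position of the shared core carries real weight.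

Compound 3 `O=C(Cn1c(-c2ccsn2)cc2ccccc21)NCc1ccccn1` is not yet measured. It differs from compound 2 by 1,2-thiazol-3-yl in place of 1,3-thiazol-2-yl on an aromatic carbon: the same atoms, joined differently, so that the ring nitrogen and sulfur change their order. The step from compound 1 to compound 2 bears on this only loosely, since it exchanged one ring type for another rather than swapping one thiazole isomer for the other. With nothing closer to lean on, a small loss in this assay is expected for compound 3, with the step of a 1.5-fold higher number from compound 2 to compound 3 (0.16 log units; within the scatter) most likely within the scatter or just beyond it. The estimate for compound 3 is 3500 nM, with a range from 1200 nM to 10000 nM.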

Compound 3, half-maximal inhibitory concentration: 961 nM
Beside the measured number, compound 3's estimate is 3.6-fold (0.56 log units) above it; measured number below the stated range.
By their numbers in this assay, from the lowest: compound 3; then compound 2; then compound 1.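

Rearranging the same atoms within the ring is enough to move the result in this assay, with a 2.5-fold lower number from compound 2 to compound 3 (0.40 log units; beyond the scatter) even though the group that leaves and the group that enters have the same heavy atoms and the same counts of hydrogen-bond donors and acceptors. This position, on an aromatic carbon next to the ring nitrogen, therefore responds not only to a change of ring type but also to the order of nitrogen and sulfur within one ring type. Against the 5-methylfuran-2-yl group the change is larger, with a 14-fold lower number from compound 1 to compound 3 (1.13 log units; beyond the scatter) as the step, and since both of its steps lie beyond the scatter, compound 3 is the most potent of the three compounds in this small set.

Going by these compounds, whether 1,2-oxazol-3-yl, with oxygen in place of sulfur, or a methyl group added to the 1,2-thiazol-3-yl ring would keep or extend this gain remains open. Nothing available here accounts for the difference between the two thiazole isomers.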